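One More Hydroxymethyl at a Chain End

A few compounds are considered here, and "the series" means these few. Any claim that something is new, unique, unknown or untested is made for them only; others in the source may bear on it.

In an ADME assay on S9 fraction from liver (Mus musculus, strain CD-1) for metabolic stability, read by LC-MS, using NADPH, with stated times of 5 min and 60 min, tested at 5 uM (a higher number here means that more of the compound is left, a lower number that less of the compound is left), compound 1 `COc1cc(C2CN(C(=O)c3cc(OCCO)ccn3)C2)ccc1OCc1ccc(C2CC2)cc1` stands at 64% and compound 2 `COc1cc(C2CN(C(=O)c3cc(OC[C@@H](O)CO)ccn3)C2)ccc1OCc1ccc(C2CC2)cc1` stands at 68% while compound 3 `CCc1ccc(COc2ccc(C3CN(C(=O)c4cc(COC[C@@H](O)CO)ccn4)C3)cc2OC)cc1` stands at 26% as the lowest of the three, beyond the scatter from both others.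

Compound 4 `CCc1ccc(COc2ccc(C3CN(C(=O)c4cc(COCC(CO)(CO)CO)ccn4)C3)cc2OC)cc1` differs from compound 3 in one place, on a saturated chain carbon bound to an oxygen on a saturated carbon, where 2-hydroxy-1,1-bis(hydroxymethyl)ethyl takes the place of 1,2-dihydroxyethyl (2-hydroxy-1,1-bis(hydroxymethyl)ethyl in place of 1,2-dihydroxyethyl on a saturated chain carbon bound to an oxygen on a saturated carbon).

For the measured compounds named here, one measured step bears on this change. It also puts hydroxymethyl on a saturated chain carbon: a number 4 percentage points higher from compound 1 to compound 2 (within the scatter) is all that this swap of hydrogen for hydroxymethyl gave. Going by the values given here, it is a loose guide, since compound 1 and compound 2 differ from compound 3 in more than one place, and no measured step starts from compound 3.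

The expected outcome in this assay is therefore no shift beyond the scatter, with an estimated a number 4 percentage points higher from compound 3 to compound 4 (within the scatter) as the step. Compound 4 is expected at 30% with 14% and 50% as the estimated ends of its range.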

Compound 4, percent of the compound remaining: 71%
Beside the measured number, compound 4's estimate is 41 percentage points below it, and the stated range ends below it.
By their numbers in this assay, from the lowest: compound 3; then compounds 1, 2 and 4 (each within the scatter of the next).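

At this place, on a saturated chain carbon bound to an oxygen on a saturated carbon, putting 2-hydroxy-1,1-bis(hydroxymethyl)ethyl in place of 1,2-dihydroxyethyl gives a number 45 percentage points higher from compound 3 to compound 4 (beyond the scatter) in this assay. For the compounds shown here, the only earlier step, a number 4 percentage points higher from compound 1 to compound 2 (within the scatter), was a different change on a different pair of compounds, so a small result there did not carry over to this one. The data at hand offer no explanation for the size of this step.

The compounds shown leave open which part of the change matters, since the entering group has more heavy atoms than the leaving group and lacks its defined stereocentre. They also leave open how an amine or a carboxylic acid at this chain end would fare in this assay.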